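This account rests on a few compounds, and the source may have more. Where it says the series, first, only, none or still open, it means among the compounds named here.

In a functional assay on GBM2 cells (Homo sapiens) for antiproliferative activity, read by WST assay, with a stated time of 72 h (on this read-out lower numbers stand for stronger inhibition and higher numbers for weaker inhibition), compound 1 `O=C(Nc1ccc(Cl)c(Cl)c1)Nc1cc2ncncc2cc1OCc1cccc(F)c1` gives 1500 nM, while compound 2 `O=C(Nc1cccc(F)c1)Nc1cc2ncncc2cc1OCc1cccc(Cl)c1` gives 7800 nM. Compound 1 therefore holds the lower of the two numbers and is the stronger inhibitor, and the gap between them lies beyond the usual scatter of repeated measurements.

The next compound to be tested is compound 3 `O=C(Nc1ccccc1F)Nc1cc2ncncc2cc1OCc1cccc(F)c1`. It keeps the shared core of compound 1 but carries 2-fluorophenyl in place of 3,4-dichlorophenyl on an amide-type nitrogen.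

Within the data shown here, no two measured compounds differ in one place only, so no single change has a measured size yet, and any forecast here is rough. Among the measured compounds shown here, the only other guide is compound 2 at 7800 nM, whose number stands higher. A move away from the better of the two measured compounds is therefore expected to lead to a weaker result, with a higher number, beyond the scatter. The expected change is a 4.0-fold higher number from compound 1 to compound 3 (0.60 log units; beyond the scatter). The estimate for compound 3 is 6000 nM, with an expected range from 2000 nM to 20000 nM.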

Compound 3, half-maximal inhibitory concentration: 6400 nM
Compound 3: the middle estimate sits 1.1-fold (0.03 log units) below what was measured, and the stated range covers the measured number.
By their numbers in this assay, from the lowest: compound 1; then compounds 3 and 2 (each within the scatter of the next).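

In this assay, among these compounds, putting 2-fluorophenyl in place of 3,4-dichlorophenyl on the amide-type nitrogen gives the first single change with a measured size in this set (a 4.3-fold higher number from compound 1 to compound 3 (0.63 log units; beyond the scatter)), and that size lies beyond the scatter. It shows that, with the rest of compound 1 held fixed, the group on this nitrogen alone can shift the number, and that this particular exchange moves it toward weaker inhibition. No measurement here bears on why the number rises, so the step stands as an observation without an explanation.

This one step removes both chlorine atoms and brings in a fluorine atom, so the share of each part in the change remains unresolved. Also open, from the compounds shown here alone, is how the number would respond to 4-chlorophenyl, 3-chlorophenyl or plain phenyl on this nitrogen, or to a phenyl ring carrying an amine or a carboxylic acid, any of which would help show which features of 3,4-dichlorophenyl matter most.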